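This account rests on a few compounds, and the source may have more. Where it says the series, first, only, none or still open, it means among the compounds named here.

In a functional assay on HeLa cells (Homo sapiens) for inhibition, read by MTT assay, with a stated time of 48 h (on this read-out lower numbers stand for stronger inhibition and higher numbers for weaker inhibition), compound 1 (`CCOC(=O)C1=C(N/N=C(/C#N)C(=O)OCC)Nc2[nH]nc(C)c2C1c1ccc(N(C)C)cc1`) gives 39200 nM and compound 2 (`CCOC(=O)C1=C(N/N=C(/Br)c2ccccc2)Nc2[nH]nc(C)c2C1c1ccc(N(C)C)cc1`) gives 75700 nM on a shared core. Going by the values given here, these are the only two numbers so far, and they lie within the scatter of each other, so compound 2 cannot be ranked against compound 1. Compound 3 (`CCOC(=O)C1=C(N/C=N/c2ccccn2)Nc2[nH]nc(C)c2C1c1ccc(N(C)C)cc1`) keeps that core and differs from compound 2 in one place, on an amine nitrogen. The change is a group of 8 heavy atoms (6 carbon, 2 nitrogen; one six-membered aromatic ring with 1 hetero atom) in place of a group of 9 heavy atoms (7 carbon, 1 nitrogen, 1 bromine; one six-membered aromatic ring of carbon only), on an amine nitrogen and it puts a six-membered aromatic ring with 1 hetero atom where compound 2 has a six-membered aromatic ring of carbon only. Among the compounds with values here, one measured step bears on this, a 1.9-fold higher number from compound 1 to compound 2 (0.29 log units; within the scatter) at that same amine nitrogen, and it stayed within the scatter although the two groups differ widely in make-up. Within the data shown here, a single step is thin evidence, and no measured compound yet carries a hetero atom in a ring of this group. Even so, no step beyond the scatter is expected in this assay in either direction. The estimated step (a 1.4-fold lower number from compound 2 to compound 3 (0.14 log units; within the scatter)) is expected to stay within the scatter. For compound 3 the expected value is 55000 nM with an estimated range from 18000 nM to 160000 nM in this measurement.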

Compound 3, half-maximal inhibitory concentration: 29200 nM
Compound 3: middle estimate off by 1.9-fold (0.27 log units), on the high side, within the range that was stated.
By their numbers in this assay, from the lowest: compounds 3, 1 and 2 (each within the scatter of the next, the first and the last beyond it).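

Going by these compounds alone, this position can move the number: in this assay, the swap gives a 2.6-fold lower number from compound 2 to compound 3 (0.41 log units; beyond the scatter), the first step here beyond the scatter, though only a modest one. The group in compound 3 does not set itself apart from every other group at this amine nitrogen, however, as the comparison with the ring-free group gives a 1.3-fold lower number from compound 1 to compound 3 (0.13 log units; within the scatter), which stays within the scatter. The swap from compound 2 to compound 3 removes the bromine and also puts a hetero atom into the six-membered aromatic ring, and nothing available explains the step or assigns it to either change.

These compounds leave open which of those two differences matters, and a group with the same chain as in compound 3 but with a six-membered aromatic ring of carbon only would help to separate them. They also leave open whether a quite different group on this amine nitrogen, such as a carboxylic acid or a simple alkyl amine, would take the number further from that of compound 3 (29200 nM) in either direction.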